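Swapping hydroxy for chloro in a cell toxicity test

The compounds below may be only part of what the source reports. "The series", "measured", "known", "first", "only" and "open" are said of these compounds alone.

Compound 1 `Cc1ccc([S+]([O-])c2cccc(N)c2C#N)cc1`: > 200000 nM (a limit)
Compound 2 `Cc1cc(O)cc(S(=O)(=O)c2cccc(N)c2C#N)c1`: 167000 nM
Compound 3 `N#Cc1c(N)cccc1S(=O)(=O)c1ccc(Cl)cc1`: > 5000 nM (a limit)

These compounds were tested in a functional assay on MT4 cells (Homo sapiens) for cytotoxicity; a lower number here means a stronger inhibitor, a higher number a weaker inhibitor. Here a high number is the welcome result, since it means that cells tolerate the compound. Among the compounds with values here, compound 2 gives 167000 nM in this assay, and this is the only true number in the set. The entries for the other two compounds are limits of the assay, so they cannot be ranked against it.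

The next compound, compound 4 `Cc1cc(Cl)cc(S(=O)(=O)c2cccc(N)c2C#N)c1`, keeps the methyl group of compound 2 and changes one substituent: chloro in place of hydroxy on an aromatic carbon. In words, this is chloro in place of hydroxy on an aromatic carbon. Within the data shown here, no measured pair of compounds shows this swap directly, so any forecast is uncertain.

Among the measured compounds shown here, the only guide is thin. Compound 3 carries a chloro group, and its entry of > 5000 nM is a limit. That leaves room for a chloro compound to score well under the value of compound 2. A moderate move toward a lower number, somewhat beyond the usual scatter, is therefore expected, and the estimated change is a 4.2-fold lower number from compound 2 to compound 4 (0.62 log units; beyond the scatter). For compound 4 the estimated value is 40000 nM, with an expected range from 8000 nM to 200000 nM.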

Compound 4, half-maximal inhibitory concentration: > 200000 nM
Compound 4: only a limit was reported; the forecaster's own chance of this, stated with the estimate: 35%; middle value at least 5.0-fold (0.69 log units) from the limit.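

In this assay, the entry for compound 4 is a limit, > 200000 nM, and not a number. The earlier compounds shown here offered no direct pair for this swap, and now the first one shows that chloro in place of hydroxy at this position, with the methyl group kept, gives no sign of a lower number and so no sign of greater harm to the cells: the change is an at least 1.1-fold higher number from compound 2 to compound 4 (0.07 log units; that floor lies within the scatter), which means chloro cannot be ranked above hydroxy on this evidence. The true size of the step stays unknown, because the reading stops at a ceiling: the limit of > 200000 nM in this assay, at which 2 of the 4 values shown sit.

The compounds shown leave open whether chloro and hydroxy differ at all in how well cells tolerate them, since a real gap could be very small or much larger than this floor. They also leave open whether a different group at this position, such as an amine or a carboxylic acid, or a longer chain in place of the methyl group, would finally bring a true number within reach of this test.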